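Shifting One Chlorine on an Aromatic Ring

The source may report more compounds than this note shows. Statements on the series, on what has been measured and on what is new or still open speak of the compounds shown alone.

Within the data shown here, in a functional assay on PC-3 cells (Homo sapiens) for cytotoxicity, read by MTT assay (on this read-out higher numbers stand for weaker inhibition and lower numbers for stronger inhibition), only two compounds have numbers so far. Compound 1 (`COc1ccc2cc([C@H](C)c3nnc(SCc4ccccc4)n3-c3ccc(Cl)cc3)ccc2c1`) gives 14200 nM and compound 2 (`COc1ccc2cc([C@H](C)c3nnc(SCc4c(Cl)cccc4Cl)n3-c3cccc(Cl)c3)ccc2c1`) gives 165000 nM as the higher of the two numbers. That gap lies beyond the scatter of repeated measurements, so compound 2 is the weaker inhibitor of this pair. These two compounds differ in more than one place, so their gap cannot be pinned on any single group.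

Compound 3 (`COc1ccc2cc([C@H](C)c3nnc(SCc4c(Cl)cccc4Cl)n3-c3ccc(Cl)cc3)ccc2c1`) differs from compound 2 in one place only: 4-chlorophenyl in place of 3-chlorophenyl on an aromatic nitrogen puts 4-chlorophenyl in place of 3-chlorophenyl on an aromatic nitrogen. The (2,6-dichlorobenzyl)sulfanyl group stays as it is. Among the measured compounds shown here, no measured pair shows this swap alone, so any forecast is loose. Compound 3 does share its 4-chlorophenyl with compound 1, which reaches 14200 nM in this assay with a different sulfanyl group. This suggests a modest move toward stronger inhibition. The expected change is a 3.3-fold lower number from compound 2 to compound 3 (0.52 log units; beyond the scatter) on this scale, and it may not clear the scatter by much. For compound 3 the estimated value is 50000 nM with an expected range from 14000 nM to 170000 nM in this measurement.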

Compound 3, half-maximal inhibitory concentration: 34700 nM
Estimate against measurement, compound 3: 1.4-fold (0.16 log units) above; low and high end bracket the measured number.
By their numbers in this assay, from the lowest: compound 1; then compound 3; then compound 2.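

The two compounds hold the same atoms, joined differently. The swap of 3-chlorophenyl for 4-chlorophenyl on the aromatic nitrogen isolates where one chlorine sits. In this assay it gives a 4.8-fold lower number from compound 2 to compound 3 (0.68 log units; beyond the scatter), so the position of this single chlorine changes the result on its own, with the (2,6-dichlorobenzyl)sulfanyl group unchanged. With 4-chlorophenyl held in place, the other single change, 2,6-dichlorophenyl in place of phenyl on the saturated chain carbon bound to a sulfur, gives a 2.4-fold higher number from compound 1 to compound 3 (0.39 log units; beyond the scatter), so the unresolved gap between compound 1 and compound 2 now divides into two single-place steps, each beyond the scatter. No measurement here gives a reason for either step.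

Going by these compounds, it remains open whether moving the chlorine would shift the number in the same way if the sulfur carried a plain benzyl group, as in compound 1, rather than the 2,6-dichlorobenzyl group. The compounds shown also leave open how 2-chlorophenyl, or a ring carrying a methoxy group or a nitrile in place of the chlorine, would compare on the aromatic nitrogen.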